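This account rests on a few compounds, and the source may have more. Where it says the series, first, only, none or still open, it means among the compounds named here.

Measured compounds in a functional assay on HBL-100 cells (Homo sapiens) for inhibition, read by sulforhodamine B assay, with a stated time of 48 h; on this read-out lower numbers stand for stronger inhibition of growth and higher numbers for weaker inhibition of growth: compound 1 `COC(=O)[C@@]1(C)CCC=C2[C@@H]1CC[C@@H](C)[C@]2(C)Cc1c[nH]c2ccc(Cl)cc12` gives 17000 nM; compound 2 `COC(=O)[C@@]1(C)CCC=C2[C@@H]1CC[C@@H](C)[C@]2(C)Cc1c(C)[nH]c2ccccc12` gives 14000 nM; compound 3 `COC(=O)[C@@]1(C)CCC=C2[C@@H]1CC[C@@H](C)[C@]2(C)Cc1c(C)[nH]c2ccc(Cl)cc12` gives 15000 nM.

Compound 3 differs from compound 1 by methyl in place of hydrogen on an aromatic carbon, and this gave a 1.1-fold lower number from compound 1 to compound 3 (0.05 log units; within the scatter). The cores of compound 1 and compound 2 differ, but that difference is not broken down here; their values lie within the scatter of each other. Compound 4 `COC(=O)[C@@]1(C)CCC=C2[C@@H]1CC[C@@H](C)[C@]2(C)Cc1c(C)[nH]c2c(C)cccc12` is not yet measured and differs from compound 2 by methyl in place of hydrogen on an aromatic carbon. Going by the values given here, this is the same kind of change as the one from compound 1 to compound 3, but not the same: there the methyl enters on a five-membered aromatic ring with one nitrogen, next to the ring nitrogen and next to the ring atom that bears a large group, whereas here it enters on a six-membered aromatic ring of carbon only, ortho to a fused ring and meta to a fused ring. Because a 1.1-fold lower number from compound 1 to compound 3 (0.05 log units; within the scatter) stayed within the scatter, the corresponding step is expected to be small, no change at the digits printed from compound 2 to compound 4 (within the scatter). Compound 4 is therefore estimated at 14000 nM, likely between 7000 nM and 28000 nM.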

Compound 4, concentration for 50% growth inhibition: 16000 nM
Estimate against measurement, compound 4: 1.1-fold (0.06 log units) below; low and high end bracket the measured number.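

In this assay, methyl in place of hydrogen on an aromatic carbon of the six-membered aromatic ring of carbon only gave a 1.1-fold higher number from compound 2 to compound 4 (0.06 log units; within the scatter), so the step is small here as well. Set beside the step on the other core, the two show no difference that can be told from scatter: the same change on two cores in this assay, a 1.1-fold lower number (0.05 log units; within the scatter) from compound 1 to compound 3 and a 1.1-fold higher number (0.06 log units; within the scatter) from compound 2 to compound 4, 1.3-fold (0.11 log units) apart, within the scatter of two such steps. Going by these compounds alone, this shows only that the change stayed small in both cases; the methyl enters a different ring in each, and steps this small do not show that its place has no influence, nor that the same would hold on other cores.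

The compounds shown leave open whether a different group at the same place, such as an amine or a carboxylic acid, would move the number beyond the scatter. They also leave open whether any change to the shared core would do so.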